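The source may report more compounds than this note shows. Statements on the series, on what has been measured and on what is new or still open speak of the compounds shown alone.

Compound 1, `COCCOc1ccc2c(C(=O)NCC3CCC(F)(F)CC3)c(Cl)ccc2n1`, in an assay on HEK293 cells for antagonist activity at P2X purinoceptor 7 (Homo sapiens), read by fluorescence, with stated times of 20 min and 30 min (on this read-out lower numbers stand for stronger inhibition and higher numbers for weaker inhibition), gives 25 nM.
Compound 2, `O=C(NCC1CCC(F)(F)CC1)c1c(Cl)ccc2nc(C3=CCCC3)ccc12`, in this assay gives 36 nM.

Within the data shown here, of the two compounds measured so far, compound 2 has the higher number, but its nearest neighbour is compound 1, and the step of a 1.4-fold higher number from compound 1 to compound 2 (0.16 log units; within the scatter) lies within the scatter, so the two cannot be told apart on these data. Compound 3, `O=C(NCC1CCC(F)(F)CC1)c1c(Cl)ccc2nc(C3CCCC3)ccc12`, is not yet measured. Going from compound 2 to compound 3, the change is cyclopentyl in place of cyclopent-1-en-1-yl on an aromatic carbon. Among the measured compounds shown here, only one measured step bears on this: the step of a 1.4-fold higher number from compound 1 to compound 2 (0.16 log units; within the scatter) exchanged a different group at the same place and left the number essentially unchanged. Nothing measured here shows what saturating the ring does, so the expectation for compound 3 is a step of about a 1.1-fold higher number from compound 2 to compound 3 (0.05 log units; within the scatter), no change beyond the scatter. Compound 3 is therefore estimated at 40 nM, with a range of 15 nM to 110 nM.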

Compound 3, half-maximal inhibitory concentration: 94 nM
Estimate against measurement, compound 3: 2.4-fold (0.37 log units) below; measured number inside the range.
By their numbers in this assay, from the lowest: compounds 1 and 2 (each within the scatter of the next); then compound 3.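

In this assay, removing the one double bond outside aromatic rings while keeping the five-membered carbon ring gives a 2.6-fold higher number from compound 2 to compound 3 (0.42 log units; beyond the scatter) and so moves the number beyond the scatter, which shows that this position next to the ring nitrogen responds to a change as small as that double bond. The exchange of 2-methoxyethoxy for cyclopentyl at the same carbon gives a 3.8-fold higher number from compound 1 to compound 3 (0.58 log units; beyond the scatter) and thus also lies beyond the scatter, so not every group placed here matches 2-methoxyethoxy, as cyclopent-1-en-1-yl did. Nothing available explains why the double bond matters.

On these data alone, how an amine, a carboxylic acid or an open chain such as propyl on this carbon would compare remains open. As far as these compounds go, it is also open whether the double bond would count the same way in a six-membered ring, as with cyclohexyl against cyclohexenyl.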